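A few compounds are considered here, and "the series" means these few. Any claim that something is new, unique, unknown or untested is made for them only; others in the source may bear on it.

Measured so far in a functional assay on K562 cells (Homo sapiens) for inhibition, read by trypan blue exclusion, with a stated time of 48 h; on this read-out higher numbers stand for weaker inhibition and lower numbers for stronger inhibition:
compound 1 `NC(=O)c1cc(Br)ccc1NC(=O)/C=C/c1ccccc1`: 5000 nM
compound 2 `Cc1ccc(/C=C/C(=O)Nc2ccc(Cl)cc2C(N)=O)cc1`: 6300 nM
compound 3 `NC(=O)c1cc(I)ccc1NC(=O)/C=C/c1ccccc1`: 570 nM

Compound 3 has the lowest number of the three, and both other compounds lie beyond the scatter from it. The next compound, compound 4 `Cc1ccc(/C=C/C(=O)Nc2ccc(I)cc2C(N)=O)cc1`, keeps the iodo group of compound 3 and turns phenyl into 4-methylphenyl, with methyl in place of hydrogen on an aromatic carbon, para to a large group (methyl in place of hydrogen on an aromatic carbon).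

Among the measured compounds shown here, no measured step isolates this change. For the measured compounds named here, the only single-place step is an 8.8-fold lower number from compound 1 to compound 3 (0.94 log units; beyond the scatter), which is iodo in place of bromo, a modest step at a different place. It shows how much the halogen can matter, but not what methyl does. Compound 2 does carry the 4-methylphenyl group, but with chloro instead of bromo, so it differs from compound 1 in two places. Even so, compound 2 at 6300 nM and compound 1 at 5000 nM lie within the scatter of each other. Nothing here points to a large shift from methyl, so no step beyond the scatter is expected, though the evidence is indirect. The expected step is a 1.0-fold lower number from compound 3 to compound 4 (0.02 log units; within the scatter). Compound 4 is estimated at 550 nM, with an expected range of 180 nM to 1800 nM.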

Compound 4, half-maximal inhibitory concentration: > 10000 nM
Compound 4 gave a limit, no number; the forecaster's own chance of this, stated with the estimate: 3%; middle value at least 18-fold (1.25 log units) from the limit.
By their numbers in this assay, from the lowest: compound 3; then compounds 1 and 2 (each within the scatter of the next). At a limit, above all of these: compound 4.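

Compound 4 stands at a limit, not a number, in this assay: the limit of > 10000 nM in this assay, at which 1 of the 4 values shown sits. Among the compounds shown here, with iodo held fixed, methyl in place of hydrogen on an aromatic carbon, para to a large group, gives an at least 17-fold higher number from compound 3 to compound 4 (1.24 log units; beyond the scatter), so this position, which no earlier single-place step had read, responds strongly to one added carbon. With the 4-methylphenyl group held fixed, iodo in place of chloro gives an at least 1.5-fold higher number from compound 2 to compound 4 (0.20 log units; that floor lies within the scatter), a floor within the scatter, so the lower number that iodo brought with phenyl, an 8.8-fold lower number from compound 1 to compound 3 (0.94 log units; beyond the scatter), does not appear in this pair, and the iodo gain seen with phenyl does not carry over to 4-methylphenyl.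

The compounds shown carry only hydrogen and methyl at this position, so it stays open whether a fluoro, a methoxy or an ethyl group there would behave as methyl does. The limit also leaves open how far compound 4 lies beyond it, and with that the full size of both new steps.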